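The compounds below may be only part of what the source reports. "The series", "measured", "known", "first", "only" and "open" are said of these compounds alone.

Measured compounds:
Compound 1, `CNC(=O)c1cc(Oc2ccc3nc(Nc4cccc(Br)c4)ncc3c2)ccn1`, in a physicochemical assay for solubility, at pH 7 (a lower number here means a less soluble compound, a higher number a more soluble compound), gives < 1000 nM, a limit of the assay.
Compound 2, `CNC(=O)c1cc(Oc2ccc3nc(Nc4cccc(C(F)(F)F)c4)ncc3c2)ccn1`, in this assay gives < 1000 nM, again a limit.
Compound 3, `CNC(=O)c1cc(Oc2ccc3nc(Nc4ccc(Br)cc4)ncc3c2)ccn1`, in this assay gives < 1000 nM, also a limit.

All three values sit at the same point, (the limit of < 1000 nM in this assay, at which 3 of the 3 values shown sit), so none of the steps between them can be read. From compound 1 to compound 2 the change is trifluoromethyl in place of bromo on an aromatic carbon, and the step is a step that the two limits leave unreadable from compound 1 to compound 2. The cores of compound 1 and compound 3 differ by 4-bromophenyl in place of 3-bromophenyl on a nitrogen on an aromatic ring, with the step that the two limits leave unreadable from compound 1 to compound 3; the step that the two limits leave unreadable from compound 2 to compound 3 is likewise unreadable.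

Compound 4, `CNC(=O)c1cc(Oc2ccc3nc(Nc4ccc(C(F)(F)F)cc4)ncc3c2)ccn1`, is not yet measured in this assay. It differs from compound 3 by trifluoromethyl in place of bromo on an aromatic carbon. This is the same kind of change as that from compound 1 to compound 2, but the place differs: there the trifluoromethyl sits meta to a large group, here para to a large group. Since the step that the two limits leave unreadable from compound 1 to compound 2 left compound 2 at the limit, compound 4 is expected to show a step that the limit leaves unreadable from compound 3 to compound 4 and to remain at that limit too. Compound 4 is estimated at 400 nM, in a range from 80 nM to 1500 nM.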

Compound 4, solubility: < 1000 nM
Compound 4 gave a limit, no number (the forecaster's own chance of this, stated with the estimate: 85%); the middle value is on the limit's open side.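

In this assay compound 4 gives < 1000 nM as a limit of the assay. For the compounds shown here, no step among compound 1, compound 2, compound 3 and compound 4 can be read, as all four share one point: the limit of < 1000 nM in this assay, at which 4 of the 4 values shown sit. The compounds shown leave open how far their true values lie from one another, and whether either change of group or place alters the reading at all.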